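A few compounds are considered here, and "the series" means these few. Any claim that something is new, unique, unknown or untested is made for them only; others in the source may bear on it.

Of the compounds shown here, three with a shared core have been measured in a functional assay on NCI-H522 cells (Homo sapiens) for inhibition, read by colorimetric assay and sulforhodamine B assay, with a stated time of 48 h (a higher number here means a weaker inhibitor of growth, a lower number a stronger inhibitor of growth), and they differ only in the group on a carbonyl carbon. Compound 1 (`CCCCCCCCCCCC[C@@H](O)[C@H]1CC[C@H]([C@H](O)CCCCCCCCCCNC(=O)c2cccs2)O1`) gives 1100 nM, the lowest of the three numbers. Compound 2 (`CCCCCCCCCCCC[C@@H](O)[C@H]1CC[C@H]([C@H](O)CCCCCCCCCCNC(=O)c2ccoc2)O1`) gives 10000 nM, and compound 3 (`CCCCCCCCCCCC[C@@H](O)[C@H]1CC[C@H]([C@H](O)CCCCCCCCCCNC(=O)c2cncs2)O1`) gives 19100 nM.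

Compound 4 (`CCCCCCCCCCCC[C@@H](O)[C@H]1CC[C@H]([C@H](O)CCCCCCCCCCNC(=O)c2ccnn2C)O1`) has not yet been measured. It departs from compound 1 at that same place, with 1-methyl-1H-pyrazol-5-yl in place of thiophen-2-yl on a carbonyl carbon.

Going by the values given here, two measured steps bear on this change, since both also remove thiophen-2-yl. One is modest, a 9.1-fold higher number from compound 1 to compound 2 (0.96 log units; beyond the scatter), and the other is large, a 17-fold higher number from compound 1 to compound 3 (1.24 log units; beyond the scatter). The remaining step, a 1.9-fold higher number from compound 2 to compound 3 (0.28 log units; within the scatter), lies within the scatter, so those two replacements cannot be told apart. Three compounds establish no general rule, and none of them carries 1-methyl-1H-pyrazol-5-yl, so the forecast remains uncertain. Even so, a step of similar size toward a higher number is expected in this assay, in line with a 9.1-fold higher number from compound 1 to compound 2 (0.96 log units; beyond the scatter) and a 17-fold higher number from compound 1 to compound 3 (1.24 log units; beyond the scatter). The expected change is an 11-fold higher number from compound 1 to compound 4 (1.04 log units; beyond the scatter). For compound 4 the estimated value is 12000 nM, with an expected range of 3500 nM to 35000 nM.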

Compound 4, concentration for 50% growth inhibition: 1410 nM
The estimate for compound 4 lay 8.5-fold (0.93 log units) above the measured number, and the stated range ends above it.
By their numbers in this assay, from the lowest: compounds 1 and 4 (each within the scatter of the next); then compounds 2 and 3 (each within the scatter of the next).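

In this assay, removing thiophen-2-yl from the carbonyl carbon does not by itself raise the number: with 1-methyl-1H-pyrazol-5-yl in its place, the result is a 1.3-fold higher number from compound 1 to compound 4 (0.11 log units; within the scatter), so compound 1 and compound 4 cannot be told apart. The earlier replacements had both gone toward a higher number, but the same new group gives a 7.1-fold lower number from compound 2 to compound 4 (0.85 log units; beyond the scatter) and a 14-fold lower number from compound 3 to compound 4 (1.13 log units; beyond the scatter), so among these four compounds the outcome depends on which five-membered aromatic ring is attached. Ring sulfur is also not needed for a number at this level, since the ring of compound 4 holds none, and compound 3 goes against any link between sulfur and a low number, as its ring holds sulfur too.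

Nothing available here explains why these rings differ. The compounds shown leave open whether the methyl on the pyrazole matters, which an unmethylated 1H-pyrazol-5-yl would test, and whether a six-membered ring such as phenyl or pyridinyl, or a simple acetyl group, would be tolerated on the same carbonyl carbon.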